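A Third Methoxy on the Carbonyl-Side Ring

The source may hold more compounds than are shown below. What is called first, only, known or untested is meant among the compounds shown, and "the series" means these compounds.

Three compounds share one core and differ only in the ring attached to the carbonyl carbon. In a functional assay on NCI-H226 cells (Homo sapiens) for cytotoxicity, read by sulforhodamine B assay, with a stated time of 48 h, tested at 0.1 uM (a higher number here means a weaker effect of the compound at the concentration tested, a lower number a stronger effect), compound 1 `COc1cc(-c2cc(/C=C/C(=O)c3ccc(N)cc3)[nH]n2)cc(OC)c1OC` gives 98%. Compound 2 `COc1cc(-c2cc(/C=C/C(=O)c3ccc(Cl)c(Cl)c3)[nH]n2)cc(OC)c1OC` gives 103% in this assay, and compound 3 `COc1ccc(C(=O)/C=C/c2cc(-c3cc(OC)c(OC)c(OC)c3)n[nH]2)cc1OC` gives 97%. The steps among them are all small: a number 5 percentage points higher from compound 1 to compound 2 (within the scatter), a number 1 percentage points lower from compound 1 to compound 3 (within the scatter), and a number 6 percentage points lower from compound 2 to compound 3 (within the scatter). Compound 3 therefore sits within the scatter of both other compounds, and none of the three can be called stronger or weaker than another.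

Compound 4 `COc1cc(C(=O)/C=C/c2cc(-c3cc(OC)c(OC)c(OC)c3)n[nH]2)cc(OC)c1OC` differs from compound 3 by methoxy in place of hydrogen on an aromatic carbon. Going by the values given here, no measured pair shows this exact change, but all three measured steps exchange the ring on the carbonyl carbon without moving the number beyond the scatter. The expectation is therefore a step of a number 1 percentage points higher from compound 3 to compound 4 (within the scatter), meaning no change beyond the scatter. Compound 4 is estimated to give 98% in this assay, expected between 88% and 108%.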

Compound 4, a percentage reported as activity, at one concentration (the size of the read-out at that concentration, not a potency): 93%
Beside the measured number, compound 4's estimate is 5 percentage points above it, within the range that was stated.
By their numbers in this assay, from the lowest: compounds 4, 3, 1 and 2 (each within the scatter of the next).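

Where the earlier compounds exchanged a whole ring on the carbonyl carbon, this pair changes a single position on that ring, and methoxy in place of hydrogen gives a number 4 percentage points lower from compound 3 to compound 4 (within the scatter) in this assay. A methoxy group at this place, ortho to one methoxy group and meta to another, is therefore not separated from hydrogen by this read-out at the one concentration tested. Nothing available here accounts for the result in terms of the properties of the group.

The compounds shown leave open whether a different group at this position, such as a hydroxy group or a carboxylic acid, would move the number beyond the scatter. They also leave open how compound 3 and compound 4 would compare at any other concentration.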